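Swapping phenyl for 1,3-thiazol-2-yl on a nitrogen

The source may hold more compounds than are shown below. What is called first, only, known or untested is meant among the compounds shown, and "the series" means these compounds.

Measured so far in a functional assay on NCI-H460 cells (Homo sapiens) for cytotoxicity, read by MTT assay, with a stated time of 3 days; on this read-out higher numbers stand for weaker inhibition and lower numbers for stronger inhibition:
- compound 1 `N#Cc1c(O)nc(SCc2nc3ccccc3[nH]2)nc1-c1ccccc1` gives 2.5 nM
- compound 2 `N#Cc1c(Nc2ccccc2)nc(SCc2nc3ccccc3[nH]2)nc1-c1ccccc1` gives 4.54 nM

Among the compounds with values here, compound 2 has compound 1 as its only measured neighbour, and the two lie within the scatter of each other. Compound 3 `N#Cc1c(Nc2nccs2)nc(SCc2nc3ccccc3[nH]2)nc1-c1ccccc1` carries 1,3-thiazol-2-yl in place of phenyl on a nitrogen on an aromatic ring. Within the data shown here, the one measured step that bears on this is a 1.8-fold higher number from compound 1 to compound 2 (0.26 log units; within the scatter) for anilino in place of hydroxy on an aromatic carbon. Among the measured compounds shown here, no measured step replaces the phenyl itself, so this is only a loose guide. In this assay the expected change is therefore a 1.1-fold lower number from compound 2 to compound 3 (0.05 log units; within the scatter) and nothing beyond the scatter. For compound 3 the estimate is 4 nM with an expected range from 1.5 nM to 12 nM for this measurement.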

Compound 3, half-maximal inhibitory concentration: 3.37 nM
For compound 3 the middle estimate is 1.2-fold (0.07 log units) above the measured one, within the range that was stated.
By their numbers in this assay, from the lowest: compounds 1, 3 and 2 (each within the scatter of the next).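

Until now this nitrogen had been seen carrying only phenyl. In this assay, 1,3-thiazol-2-yl in its place gives a 1.3-fold lower number from compound 2 to compound 3 (0.13 log units; within the scatter), so a five-membered aromatic ring with 2 hetero atoms and 2 hydrogen-bond acceptors leaves the result within the scatter of the phenyl compound. Replacing hydroxy on the aromatic carbon with the whole (1,3-thiazol-2-yl)amino group gives a 1.3-fold higher number from compound 1 to compound 3 (0.13 log units; within the scatter), which places all three compounds within the scatter of one another. No measurement shown here offers a reason for these results.

From the compounds shown here alone, it remains open whether any group at this place can move the number beyond the scatter. A methyl or a cyclohexyl on the same nitrogen, in place of the aromatic ring, would show whether an aromatic ring is needed there at all.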